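A few compounds are considered here, and "the series" means these few. Any claim that something is new, unique, unknown or untested is made for them only; others in the source may bear on it.

Compound 1, `CC(C)[C@H](C(=O)NCc1ccccc1)c1ccc(Cl)cc1`: in a functional assay on CHO cells for agonist activity at Free fatty acid receptor 2 (Homo sapiens), read by cAMP accumulation (a higher number here means a weaker inhibitor, a lower number a stronger inhibitor), it gives only a limit, > 100000 nM, the limit described as the limit of > 100000 nM in this assay, at which 1 of the 3 values shown sits.
Compound 2, `CC(C)[C@H](C(=O)Nc1cccnn1)c1ccc(Cl)cc1`: in this assay compound 2 gives 2300 nM.
Compound 3, `CC(C)(C)[C@H](C(=O)Nc1ncc(Br)s1)c1ccc(Cl)cc1`: in this assay compound 3 gives 700 nM.

Among the numbers reported so far, compound 3 holds the lowest. Its nearest neighbour is compound 2, whose number is higher, and the gap between the two lies beyond the usual scatter. Compound 1 contributes only a limit and no number.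

Compound 4, `CN(C)c1cnc(NC(=O)[C@H](c2ccc(Cl)cc2)C(C)(C)C)s1`, is not yet measured. It differs from compound 3 in a single place: dimethylamino in place of bromo on an aromatic carbon. Within the data shown here, the one measured step, an at least 43-fold lower number from compound 1 to compound 2 (1.63 log units; beyond the scatter), concerns the group on the amide nitrogen, not a substituent on the five-membered ring, so none of the measured steps bears directly on the change from compound 3 to compound 4. Among the measured compounds shown here, with no comparable step to lean on, the exchange at this ring carbon is expected to leave the number close to where compound 3 stands, with the step of no change at the digits printed from compound 3 to compound 4 (within the scatter) expected to fall within the scatter. Compound 4 is therefore estimated at 700 nM, with a range from 250 nM to 2500 nM, pending the measurement.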

Compound 4, half-maximal inhibitory concentration: 1600 nM
Compound 4: middle estimate off by 2.3-fold (0.36 log units), on the low side; measured number inside the range.
By their numbers in this assay, from the lowest: compound 3; then compounds 4 and 2 (each within the scatter of the next). At a limit, above all of these: compound 1.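

In this assay the aromatic carbon next to the ring sulfur, two ring bonds from the ring atom that bears a large group, is shown to respond to what it carries: exchanging bromo for dimethylamino gives a 2.3-fold higher number from compound 3 to compound 4 (0.36 log units; beyond the scatter) and so costs only a modest part of the number. Among these compounds, the one step measured before this concerned the group on the amide nitrogen, whereas this step shows that the ring carbon accepts a group with more heavy atoms and a hydrogen-bond acceptor, which bromo lacks, and still gives a measurable number in the same assay. Nothing given here accounts for the direction or the size of this step.

With only bromo and dimethylamino at this carbon, the compounds shown do not separate the loss of bromine from the arrival of the amine, a question that chloro, a methyl group or a primary amine at the same place could address. They also leave open how a carboxylic acid or a longer alkyl chain at this ring carbon would move the number.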